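The source may report more compounds than this note shows. Statements on the series, on what has been measured and on what is new or still open speak of the compounds shown alone.

Measured compounds:
compound 1, `CCCS(=O)(=O)Nc1cccc2c1CCC2c1ncc[nH]1`: > 10000 nM
compound 2, `CS(=O)(=O)Nc1cccc2c1CCC2c1ncc[nH]1`: > 10000 nM
compound 3, `c1cc(-c2cn[nH]c2)c2c(c1)C(c1ncc[nH]1)CC2`: 319 nM

In a functional assay on CHO cells for agonist activity at Alpha-1D adrenergic receptor (Homo sapiens), read by FLIPR and calcium flux (a lower number here means that less compound is needed, a higher number that more compound is needed for the effect), compound 1 gives > 10000 nM, which is a limit of the assay rather than a number. Compound 2 likewise gives > 10000 nM, again only a limit. Compound 1 thus stands at the limit of > 10000 nM in this assay, at which 2 of the 3 values shown sit, and its position relative to compound 2 cannot be read, as a step that the two limits leave unreadable from compound 1 to compound 2 shows. Compound 3, by contrast, gives 319 nM, and the step of an at least 31-fold lower number from compound 1 to compound 3 (1.49 log units; beyond the scatter) is large; the same holds for an at least 31-fold lower number from compound 2 to compound 3 (1.49 log units; beyond the scatter).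

Compound 4, `Cc1n[nH]cc1-c1cccc2c1CCC2c1ncc[nH]1`, differs from compound 1 in one place: 3-methyl-1H-pyrazol-4-yl in place of (propylsulfonyl)amino on an aromatic carbon. This change closely parallels the change from compound 1 to compound 3, in which 1H-pyrazol-4-yl also replaces (propylsulfonyl)amino; the only added feature is the methyl of the 3-methyl-1H-pyrazol-4-yl group. The step of an at least 31-fold lower number from compound 1 to compound 3 (1.49 log units; beyond the scatter) is therefore the one that bears on it, and a step of similar size and direction is expected in this assay: an at least 25-fold lower number from compound 1 to compound 4 (1.39 log units; beyond the scatter). Compound 4 is accordingly expected to give 400 nM, within 100 nM to 1600 nM.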

Compound 4, half-maximal effective concentration: 634 nM
Compound 4: the middle estimate sits 1.6-fold (0.20 log units) below what was measured; the range from low to high includes it.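

In this assay, a methyl added to the 1H-pyrazol-4-yl group on this aromatic carbon gives no change beyond the scatter (a 2.0-fold higher number from compound 3 to compound 4 (0.30 log units; within the scatter)). The large gain over the sulfonamides therefore does not require an unsubstituted pyrazole, as it persists with 3-methyl-1H-pyrazol-4-yl in place of (propylsulfonyl)amino (an at least 15-fold lower number from compound 1 to compound 4 (1.19 log units; beyond the scatter)) and of methanesulfonamido (an at least 15-fold lower number from compound 2 to compound 4 (1.19 log units; beyond the scatter)). These two steps are bounds only, and the step between compound 1 and compound 2 cannot be read, as both compounds remain limits: the limit of > 10000 nM in this assay, at which 2 of the 4 values shown sit.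

From the compounds shown here alone, whether the pyrazole carries anything larger than methyl, such as an ethyl, a trifluoromethyl or an aminomethyl group, without a marked shift in the value remains open. Also open, going by these compounds, is whether another five-membered aromatic ring, such as a thiazole or an imidazole, would serve on this aromatic carbon.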